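Replacing a nitrophenyl with a phenylethenyl group

This account rests on a few compounds, and the source may have more. Where it says the series, first, only, none or still open, it means among the compounds named here.

Compound 2 `O=C(CSc1nnc(-c2ccncc2)o1)N/N=C/c1ccc([N+](=O)[O-])cc1` was tested in a functional assay on MCF7 cells (Homo sapiens) for cytotoxicity, read by MTT assay, with a stated time of 48 h (a higher number here means a weaker inhibitor, a lower number a stronger inhibitor), where it gives 31800 nM, the second highest of three numbers. Compound 3 `O=C(CSc1nnc(-c2ccncc2)o1)N/N=C/c1ccccc1[N+](=O)[O-]` gives 35600 nM, and a 1.1-fold higher number from compound 2 to compound 3 (0.05 log units; within the scatter). Compound 1 `O=C(CSc1nnc(-c2ccncc2)o1)N/N=C/c1ccc(Cl)cc1` gives 15300 nM, and a 2.1-fold higher number from compound 1 to compound 2 (0.32 log units; beyond the scatter). Compound 4 `O=C(CSc1nnc(-c2ccncc2)o1)N/N=C/C=C/c1ccccc1` has not been measured; it differs from compound 2 by 2-phenylethenyl in place of 4-nitrophenyl on a carbon with a double bond to nitrogen. Within the data shown here, the only step that bears on losing a nitro group is the one from compound 1 to compound 2, which was modest, so compound 4 is expected to return to roughly the range of compound 1, with a 1.8-fold lower number from compound 2 to compound 4 (0.25 log units; within the scatter) as the expected step. Compound 4 is thus estimated at 18000 nM, within a range from 8000 nM to 40000 nM.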

Compound 4, half-maximal inhibitory concentration: 10800 nM
Beside the measured number, compound 4's estimate is 1.7-fold (0.22 log units) above it, within the range that was stated.
By their numbers in this assay, from the lowest: compounds 4 and 1 (each within the scatter of the next); then compounds 2 and 3 (each within the scatter of the next).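

At this carbon with a double bond to nitrogen, 2-phenylethenyl gives a 2.9-fold lower number from compound 2 to compound 4 (0.47 log units; beyond the scatter) and a 3.3-fold lower number from compound 3 to compound 4 (0.52 log units; beyond the scatter) in this assay, so the benzene ring need not be attached directly to that carbon for the number to fall below those of the nitro compounds. Against the 4-chlorophenyl group, the change gives a 1.4-fold lower number from compound 1 to compound 4 (0.15 log units; within the scatter), so these two groups cannot be told apart in this assay. No measurement shown explains these steps.

From the compounds shown here alone, an amine or a carboxylic acid at this carbon remains open, as does a chain longer than 2-phenylethenyl. Also open, going by these compounds, is whether a chloro group on the ring of 2-phenylethenyl would change the number.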